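Reshaping the Carbamate Alkyl Group on a Shared Core

The compounds below may be only part of what the source reports. "The series", "measured", "known", "first", "only" and "open" are said of these compounds alone.

Compound 2 `COc1cc(C(=O)N2CCN(C(=O)c3cc(OC)c(OC)c(OC)c3)C(COC(=O)NCCC(C)C)C2)cc(OC)c1OC` gives 140 nM in a functional assay (Oryctolagus cuniculus) for inhibition of platelet-activating factor receptor (Cavia porcellus); a lower number here means a stronger inhibitor, a higher number a weaker inhibitor. For the measured compounds named here, its only measured neighbour, compound 1 `COc1cc(C(=O)N2CCN(C(=O)c3cc(OC)c(OC)c(OC)c3)C(COC(=O)NC(C)C(C)C)C2)cc(OC)c1OC`, gives 80 nM in this assay, and the step of a 1.8-fold higher number from compound 1 to compound 2 (0.24 log units; within the scatter) lies within the scatter, so the two stand level. Compound 3 `CCC(CC)NC(=O)OCC1CN(C(=O)c2cc(OC)c(OC)c(OC)c2)CCN1C(=O)c1cc(OC)c(OC)c(OC)c1` differs from compound 2 by pentan-3-yl in place of isopentyl on an amide-type nitrogen. Going by the values given here, the one measured step touching this nitrogen, a 1.8-fold higher number from compound 1 to compound 2 (0.24 log units; within the scatter), was small, so no step beyond the scatter is expected in this assay in either direction. The expected step is therefore a 1.3-fold lower number from compound 2 to compound 3 (0.10 log units; within the scatter). Compound 3 is estimated at 110 nM, with a range from 40 nM to 350 nM.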

Compound 3, half-maximal inhibitory concentration: 130 nM
Compound 3: the middle estimate sits 1.2-fold (0.07 log units) below what was measured; low and high end bracket the measured number.
By their numbers in this assay, from the lowest: compounds 1, 3 and 2 (each within the scatter of the next).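

At the amide-type nitrogen, pentan-3-yl in place of isopentyl gives a 1.1-fold lower number from compound 2 to compound 3 (0.03 log units; within the scatter) in this assay and pentan-3-yl in place of 1,2-dimethylpropyl gives a 1.6-fold higher number from compound 1 to compound 3 (0.21 log units; within the scatter) in the same read-out. Three differently branched groups of 5 carbon atoms thus stand level at this position, where earlier only two could be set side by side. No measurement offered here speaks to why these groups stand level. Going by these compounds, whether a shorter chain such as ethyl, a longer chain such as octyl, a cyclohexyl ring or a chain carrying an amine would move the number at this nitrogen stays open.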